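Shortening the anilide substituent: butoxy to methyl

The compounds below may be only part of what the source reports. "The series", "measured", "known", "first", "only" and "open" are said of these compounds alone.

Measured compounds:
compound 1 `CCc1ccccc1NS(=O)(=O)c1ccc(N2CCNC2=O)cc1`: 240 nM
compound 2 `Cc1ccccc1NS(=O)(=O)c1ccc(N2CCNC2=O)cc1`: 200 nM
compound 3 `CCCCOc1ccc(NS(=O)(=O)c2ccc(N3CCNC3=O)cc2)cc1`: 630 nM

Three sulfonamides sharing one core have been measured in a functional assay on HT-29 cells (Homo sapiens) for antiproliferative activity, read by sulforhodamine B assay, with a stated time of 48 h; a higher number here means a weaker inhibitor, a lower number a stronger inhibitor. Compound 1 gives 240 nM and compound 2 gives 200 nM; the step of a 1.2-fold lower number from compound 1 to compound 2 (0.08 log units; within the scatter) shows that trimming ethyl to methyl changes nothing that can be told from the noise. Compound 3, which carries butoxy instead, gives 630 nM and stands highest of the three, beyond the scatter from both compound 1 and compound 2.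

Compound 4 `Cc1ccc(NS(=O)(=O)c2ccc(N3CCNC3=O)cc2)cc1` has not yet been measured. It differs from compound 3 as follows: methyl in place of butoxy on an aromatic carbon. Going by the values given here, no measured step covers this exact exchange. Among the compounds with values here, the only step on record, from compound 1 to compound 2, concerns a chain shortening on a carbon bound to the ring and was within the scatter, so it says little about replacing a butoxy with a methyl. What the numbers do show is that the two methyl- or ethyl-bearing compounds, compound 1 and compound 2, sit clearly lower than the butoxy-bearing compound 3. On that basis compound 4 is expected to move toward those two, giving a step of a 2.0-fold lower number from compound 3 to compound 4 (0.29 log units; within the scatter) in this assay. Compound 4 is therefore estimated at 320 nM, with a range from 140 nM to 800 nM.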

Compound 4, half-maximal inhibitory concentration: 480 nM
Beside the measured number, compound 4's estimate is 1.5-fold (0.18 log units) below it; the measured number falls inside the stated range.
By their numbers in this assay, from the lowest: compounds 2, 1, 4 and 3 (each within the scatter of the next, the first and the last beyond it).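

In this assay, the exchange of butoxy for methyl on an aromatic carbon, para to a large group, gives a 1.3-fold lower number from compound 3 to compound 4 (0.12 log units; within the scatter), so dropping from the longer chain to a single carbon leaves a result that cannot be told apart from that of compound 3. Going by these compounds alone, the earlier gap between compound 3 and the other two therefore does not follow the size of the substituent alone, since the only new step beyond the scatter, though modest, is a 2.4-fold higher number from compound 2 to compound 4 (0.38 log units; beyond the scatter), where the methyl stays and 4-methylphenyl replaces 2-methylphenyl on the sulfonamide nitrogen, while the change from 2-ethylphenyl to 4-methylphenyl gives a 2.0-fold higher number from compound 1 to compound 4 (0.30 log units; within the scatter) and stays within the scatter. No measurement shown here offers a reason for any of these steps.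

The compounds shown leave open what hydrogen, a methoxy, an amine or a carboxylic acid would give on the aromatic carbon that carries butoxy in compound 3 and methyl in compound 4. They also leave open whether a butoxy on the sulfonamide aniline ring would fare differently elsewhere on that ring.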